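Phenyl in place of pentyl: a first estimate

The source may report more compounds than this note shows. Statements on the series, on what has been measured and on what is new or still open speak of the compounds shown alone.

In a physicochemical assay for lipophilicity, measured as octanol-water partition (a lower number here means a more polar compound, a higher number a more lipophilic compound), compound 1 (`CC(C)=CCn1cc(-c2ccccc2)nn1`) gives 2.82 and compound 2 (`CCCCCc1cn(C/C=C(/C)CCC=C(C)C)nn1`) gives 5.45 as the higher of the two numbers, a gap beyond the scatter. Compound 3 (`CC(C)=CCC/C(C)=C\Cn1cc(-c2ccccc2)nn1`) differs from compound 2 in one place: phenyl in place of pentyl on an aromatic carbon with phenyl in place of pentyl on an aromatic carbon. Among the compounds with values here, no measured pair shows this change on its own, so its size in this assay remains a judgement. Compound 3 shares its phenyl with compound 1 at 2.82 and the rest of its structure with compound 2 at 5.45 so a value between these two is expected, closer to the higher one. The expected move is a number 0.85 log units lower from compound 2 to compound 3 (beyond the scatter) downward and beyond the scatter. In this assay compound 3 is expected at 4.6 within an estimated range of 4.1 to 5.1 as the working figure.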

Compound 3, partition coefficient: 4.91
Beside the measured number, compound 3's estimate is 0.31 log units below it; measured number inside the range.
By their numbers in this assay, from the lowest: compound 1; then compound 3; then compound 2.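

On the aromatic carbon of the five-membered aromatic ring, phenyl in place of pentyl gives a number 0.54 log units lower from compound 2 to compound 3 (beyond the scatter) in this assay and so has a modest size, even though a six-membered aromatic ring enters and an open chain leaves. The other new step, 3-methylbut-2-en-1-yl in place of hydrogen on a saturated chain carbon bound to a double-bonded chain carbon, is large at a number 2.09 log units higher from compound 1 to compound 3 (beyond the scatter) and so outweighs the change on the aromatic carbon in this series. Nothing available explains the size of either step.

On these data alone, whether a similar step follows with an amine or a carboxylic acid on the same aromatic carbon remains open. Also open, as far as these compounds go, is how a longer chain in place of pentyl would compare with phenyl at this position.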